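What one methyl may do to compound 3

A few compounds are considered here, and "the series" means these few. Any claim that something is new, unique, unknown or untested is made for them only; others in the source may bear on it.

Measured in a functional assay on NB1 cells (Homo sapiens) for cytotoxicity, read by MTT assay, with a stated time of 3 days; a lower number here means a stronger inhibitor, a higher number a weaker inhibitor:
- compound 1 `N#Cc1c(O)nc(SCc2nc3ccccc3[nH]2)nc1-c1ccccc1` gives 6.57 nM
- compound 2 `N#Cc1c(Nc2ccccc2)nc(SCc2nc3ccccc3[nH]2)nc1-c1ccccc1` gives 2.5 nM
- compound 3 `N#Cc1c(-c2ccccc2)nc(SCc2nc3ccccc3[nH]2)nc1N1CCNCC1` gives 6.75 nM

Compound 3 cannot be told apart from compound 1, with a 1.0-fold higher number from compound 1 to compound 3 (0.01 log units; within the scatter) as the step. Its number is higher than that of compound 2, with a 2.7-fold higher number from compound 2 to compound 3 (0.43 log units; beyond the scatter) as the step, so it sits on the weaker side of this small set.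

Compound 4 `CN1CCN(c2nc(SCc3nc4ccccc4[nH]3)nc(-c3ccccc3)c2C#N)CC1` changes compound 3 in one place: methyl in place of hydrogen on an amine nitrogen in a ring. This is methyl in place of hydrogen on an amine nitrogen in a ring, which turns piperazin-1-yl into 4-methylpiperazin-1-yl.

Among the compounds with values here, no measured pair shows this change directly, so the evidence is indirect. The nearest guide is what happened when the whole group on an aromatic carbon was exchanged. That gave a 2.6-fold lower number from compound 1 to compound 2 (0.42 log units; beyond the scatter), and the two steps to compound 3 shown above were no larger. If replacing an entire group moved the number so little, a single added methyl is expected to do no more than that, and probably to stay within the scatter in this assay with no favoured direction.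

The estimated step is a 1.1-fold lower number from compound 3 to compound 4 (0.05 log units; within the scatter) in size. For compound 4 the expected value is 6 nM, with an estimated range from 2.5 nM to 15 nM as its likely span.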

Compound 4, half-maximal inhibitory concentration: 2.4 nM
The estimate for compound 4 lay 2.5-fold (0.40 log units) above the measured number; the whole stated range lies above it.
By their numbers in this assay, from the lowest: compounds 4 and 2 (each within the scatter of the next); then compounds 1 and 3 (each within the scatter of the next).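

A single methyl on the amine nitrogen of the piperazin-1-yl ring matters in this assay (a 2.8-fold lower number from compound 3 to compound 4 (0.45 log units; beyond the scatter)), a step of about the same size as exchanging the whole hydroxy group for anilino (a 2.6-fold lower number from compound 1 to compound 2 (0.42 log units; beyond the scatter)), so small edits at this position need not give smaller steps than whole-group exchanges. With 4-methylpiperazin-1-yl in place, the compound can no longer be told apart from the anilino compound (a 1.0-fold lower number from compound 2 to compound 4 (0.02 log units; within the scatter)), and it now separates from the hydroxy compound (a 2.7-fold lower number from compound 1 to compound 4 (0.44 log units; beyond the scatter)), which compound 3 did not do. Nothing measured here accounts for the effect of the methyl.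

As far as these compounds go, a single methyl is only one point at this nitrogen, so it remains open whether an ethyl group, a longer chain or an acetyl group there would move the number further, or back. From the compounds shown here alone, it is also open whether a methyl on the nitrogen of the anilino group would give a similar step, or whether this step belongs to the piperazine ring alone.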